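The source may report more compounds than this note shows. Statements on the series, on what has been measured and on what is new or still open speak of the compounds shown alone.

Measured so far:
compound 1 `CCCCC(Sc1ccc(OCCCOc2ccc(-c3ccccc3)cc2)cc1)C(=O)O`: 900 nM
compound 2 `CCCCC(Sc1ccc(OCCCOc2cccc(C)c2)cc1)C(=O)O`: 4800 nM

In an assay on isolated protein for inhibition of Polyunsaturated fatty acid 5-lipoxygenase (Homo sapiens), read by HPLC, with a stated time of 15 min, in the presence of a further agent that is not named here (a lower number here means a stronger inhibitor, a higher number a weaker inhibitor), compound 1 gives 900 nM, and compound 2 gives 4800 nM. For the measured compounds named here, of the two numbers known, compound 2 has the highest, so it is the weaker inhibitor here, and the gap between compound 1 and compound 2 lies beyond the usual scatter of repeated measurements.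

Compound 3 `CCCCC(Sc1ccc(OCCCOc2ccccc2OC)cc1)C(=O)O` has not yet been measured. It differs from compound 2 in one place: 2-methoxyphenyl in place of 3-methylphenyl on an oxygen on a saturated carbon, that is, 2-methoxyphenoxy in place of 3-methylphenoxy at the end of the three-carbon linker. Going by the values given here, no measured pair shows this particular exchange, so there is no step of known size to lean on. Because compound 2 already stands at 4800 nM, and the exchanged ring stays a single six-membered aromatic ring of similar size, the step of a 1.0-fold higher number from compound 2 to compound 3 (0.02 log units; within the scatter) is expected to be small, most likely within the scatter. The value of compound 3 in this assay is estimated at 5000 nM, within a range from 1500 nM to 16000 nM.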

Compound 3, half-maximal inhibitory concentration: > 10000 nM
Compound 3: no number, only a limit (the forecaster's own chance of this, stated with the estimate: 5%); middle value at least 2.0-fold (0.30 log units) away from the limit.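

This place, on an oxygen on a saturated carbon, responds to an exchange between two single-ring groups: 2-methoxyphenyl in place of 3-methylphenyl gives an at least 2.0-fold higher number from compound 2 to compound 3 (0.31 log units; beyond the scatter) in this assay. Keeping one six-membered aromatic ring of carbon only at this place is therefore not enough to hold the inhibition at the level of compound 2, something the earlier compounds could not show, as no pair among them differed in one place. Compound 3 carries only a limit, > 10000 nM, not a number, and the full size of the step stays unknown because of it: the limit of > 10000 nM in this assay, at which 1 of the 3 values shown sits.

The compounds shown leave open whether the methoxy group itself or its place on the ring drives this step; neither 3-methoxyphenyl nor 2-methylphenyl stands among them. They also do not tell how a ring carrying an amine or a carboxylic acid would fare here.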